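The source may hold more compounds than are shown below. What is called first, only, known or untested is meant among the compounds shown, and "the series" means these compounds.

Measured so far: compound 1 `COc1cc2c(Oc3ccc(NC(=O)c4nn(-c5ccccc5C(F)(F)F)c(=O)cc4C)cc3F)ccnc2cc1OCCCN1CCCC1` with 210 nM; compound 2 `COc1cc2c(Oc3ccc(NC(=O)c4nn(-c5ccccc5C(F)(F)F)c(=O)cc4C)cc3F)ccnc2cc1OCCCN1CCCCC1` with 210 nM.

In a functional assay on NCI-H460 cells (Homo sapiens) for inhibition, read by MTT assay, with a stated time of 72 h (on this read-out higher numbers stand for weaker inhibition and lower numbers for stronger inhibition), compound 1 gives 210 nM and stands level with compound 2, which gives 210 nM. Among the measured compounds shown here, the single measured step, no change at the digits printed from compound 1 to compound 2 (within the scatter), concerns only the saturated chain end. Compound 3 `COc1cc2c(Oc3ccc(NC(=O)c4nn(-c5ccc(F)c(F)c5)c(=O)cc4C)cc3F)ccnc2cc1OCCCN1CCCC1` differs from compound 1 by 3,4-difluorophenyl in place of 2-(trifluoromethyl)phenyl on an aromatic nitrogen. For the measured compounds named here, no measured step touches this aryl position, so the data give no direct guide. Compound 3 is therefore expected to stay near compound 1, estimated at 250 nM with a wide range from 60 nM to 1200 nM, an expected step of a 1.2-fold higher number from compound 1 to compound 3 (0.08 log units; within the scatter) in this assay.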

Compound 3, half-maximal inhibitory concentration: 170 nM
Beside the measured number, compound 3's estimate is 1.5-fold (0.17 log units) above it, within the range that was stated.
By their numbers in this assay, from the lowest: compounds 3, 1 and 2 (each within the scatter of the next).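

Among the compounds shown here, at the aromatic nitrogen, 3,4-difluorophenyl in place of 2-(trifluoromethyl)phenyl gives a 1.2-fold lower number from compound 1 to compound 3 (0.09 log units; within the scatter) in this assay, the first measured step at this position. Two differently substituted phenyl groups, of 8 and 10 heavy atoms, therefore read alike here, so this exchange on the aryl group does not separate the compounds. No evidence on hand accounts for this result.

As far as these compounds go, whether an unsubstituted phenyl, a pyridyl ring or a small alkyl group such as methyl on that nitrogen would read alike remains open. So does whether 3,4-difluorophenyl would give the same reading alongside the piperidin-1-yl chain end of compound 2.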